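From compound 2 to compound 4: one added methyl

The source may report more compounds than this note shows. Statements on the series, on what has been measured and on what is new or still open speak of the compounds shown alone.

In an ADME assay on Vero cells (Chlorocebus sabaeus) for cytotoxicity, read by MTT assay, with a stated time of 72 h (a lower number here means that less compound is tolerated, a higher number that more compound is tolerated), compound 2 `O=C(/C=C/c1ccccc1)OC[C@@H](O)c1ccccc1` gives 39200 nM. Compound 1 `COc1ccc([C@H](O)COC(=O)/C=C/c2ccccc2)cc1` gives 33500 nM, and compound 3 `O=C(/C=C/c1ccccc1)OC[C@H](O)c1ccccc1` gives 30300 nM. All three numbers lie within the ordinary scatter of repeated measurements, so compound 2 cannot be separated from the other two, and this small set shows no real differences yet.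

Compound 4 `Cc1ccc([C@H](O)COC(=O)/C=C/c2ccccc2)cc1` has not been measured. Its structure departs from compound 2 by one small change: methyl in place of hydrogen on an aromatic carbon. In plain terms, this is methyl in place of hydrogen on an aromatic carbon.

Two measured steps offer a guide. The more relevant one also exchanges a group for hydrogen on an aromatic carbon: replacing the methoxy of compound 1 with hydrogen gave a 1.2-fold higher number from compound 1 to compound 2 (0.07 log units; within the scatter). The other keeps the same atoms and bonds and alters only the configuration as drawn, giving a 1.3-fold lower number from compound 2 to compound 3 (0.11 log units; within the scatter). Neither step rises above the scatter, so a methyl group, which is a modest change of the same kind, is not expected to produce a clear shift in this assay in either direction.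

The estimated change is a 1.1-fold lower number from compound 2 to compound 4 (0.05 log units; within the scatter). For compound 4 the expected value is 35000 nM, with an estimated range from 20000 nM to 60000 nM.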

Compound 4, half-maximal cytotoxic concentration: > 200000 nM
Compound 4 gave a limit, no number (the forecaster's own chance of this, stated with the estimate: 5%); middle value at least 5.7-fold (0.75 log units) away from the limit.
By their numbers in this assay, from the lowest: compounds 3, 1 and 2 (each within the scatter of the next). At a limit, above all of these: compound 4.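

In this assay compound 4 gives > 200000 nM, which is a limit of the assay and not a number. At this place on the six-membered aromatic ring, para to a large group, methyl in place of hydrogen gives an at least 5.1-fold higher number from compound 2 to compound 4 (0.70 log units; beyond the scatter), and methyl in place of methoxy gives an at least 5.9-fold higher number from compound 1 to compound 4 (0.77 log units; beyond the scatter). The earlier step between hydrogen and methoxy at the same place, a 1.2-fold higher number from compound 1 to compound 2 (0.07 log units; within the scatter), made the position look indifferent to its substituent, but the methyl now shows that one small group here can move the result beyond the scatter, with compounds 1 and 2 both standing clearly apart from compound 4.

Going by these compounds, how far the number of compound 4 really lies beyond the limit stays unknown, as does whether an ethyl group, a chlorine atom or a hydroxymethyl group at this place would follow methyl or stay with hydrogen and methoxy. Also open is whether the effect of the methyl depends on the configuration at the chain carbon, since the only comparison of configuration shown has no methyl on the ring: the fact that compounds 2 and 3 differ only in the configuration as drawn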